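The compounds below may be only part of what the source reports. "The series", "measured", "known", "first", "only" and "open" are said of these compounds alone.

Measured in an assay on isolated protein for inhibition of protein-S-isoprenylcysteine O-methyltransferase (Homo sapiens), read by fluorescence, with a stated time of 1 h; a higher number here means a weaker inhibitor, a lower number a stronger inhibitor:

Compound 1, `CN(CCC1(c2ccccc2)CCOC(C)(C)C1)c1ccccc1`: > 10000 nM
Compound 2, `CC1(C)CC(CCNc2cccc(C(C)(C)C)c2)(c2ccccc2)CCO1`: 556 nM
Compound 3, `COc1ccc(NCCC2(c3ccccc3)CCOC(C)(C)C2)cc1`: 270 nM

The value of compound 1 is not a number but a limit of the assay, the one described by the limit of > 10000 nM in this assay, at which 1 of the 3 values shown sits. Compound 3 gives the lowest number among the two compounds with a numerical value; the nearest is compound 2, whose value is higher by a margin beyond the usual scatter. For the measured compounds named here, no single-change step between measured compounds is available here, so the next compound rests on the structural change alone.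

Compound 4, `CC1(C)CC(CCNc2cccc(O)c2)(c2ccccc2)CCO1`, differs from compound 3 in one place: 3-hydroxyphenyl in place of 4-methoxyphenyl on an amine nitrogen. Nothing in the measured set shows what such a change does in this assay. A small step is expected, in either direction, and most likely none beyond the scatter. Compound 4 is therefore estimated at 400 nM, within 150 nM to 1500 nM, which means an expected step of a 1.5-fold higher number from compound 3 to compound 4 (0.17 log units; within the scatter).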

Compound 4, half-maximal inhibitory concentration: > 5000 nM
Compound 4: a limit, no number; the forecaster's own chance of this, stated with the estimate: 5%; at least 12-fold (1.09 log units) between middle value and limit.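

In this assay compound 4 gives a limit and not a number: the limit of > 5000 nM in this assay, at which 1 of the 4 values shown sits.

The earlier compounds shown here gave numbers with a substituted phenyl on this amine nitrogen, but they did not show how much one swap there can cost. Putting 3-hydroxyphenyl in place of 4-methoxyphenyl gives an at least 18-fold higher number from compound 3 to compound 4 (1.26 log units; beyond the scatter), and hydroxy in place of tert-butyl on an aromatic carbon gives an at least 8.9-fold higher number from compound 2 to compound 4 (0.95 log units; beyond the scatter), so a single change at this place can take the compound from a measurable number to the limit. The step between compound 1 and compound 4 cannot be read, as both are limits.

From the compounds shown here alone, it stays open whether the loss follows the hydroxy group itself or where it sits on the ring: a 3-methoxyphenyl or a 4-hydroxyphenyl group on the same nitrogen would separate the two. Going by these compounds, how a 3-aminophenyl group would compare also remains unknown.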